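Swapping a Carbamate for a Hydroxyethyl Chain on a Hydrazone

The compounds below may be only part of what the source reports. "The series", "measured", "known", "first", "only" and "open" are said of these compounds alone.

Of the compounds shown here, three built on one shared core have been tested in a functional assay on NALM-6 cells (Homo sapiens) for cytotoxicity, read by MTT assay, with a stated time of 48 h; a lower number here means a stronger inhibitor, a higher number a weaker inhibitor. Compound 1 `Nc1oc2ccc(Cl)cc2c(=O)c1/C=N/NCCO` gives 28000 nM. Compound 2 `COC(=O)N/N=C/c1coc2ccccc2c1=O` gives 309000 nM, and compound 3 `COC(=O)N/N=C/c1c(N)oc2ccccc2c1=O` gives 407000 nM. Among these, compound 3 stands at the high end of the three numbers, although its gap to compound 2 is within the scatter: the one directly measured step, a 1.3-fold higher number from compound 2 to compound 3 (0.12 log units; within the scatter), shows that placing an amino group on the aromatic carbon barely moved the read-out. Compound 1, by contrast, sits far below compound 3.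

Compound 4 `Nc1oc2ccccc2c(=O)c1/C=N/NCCO` has not yet been measured. It differs from compound 3 in a single place: 2-hydroxyethyl in place of methoxycarbonyl on an amine nitrogen. Among the measured compounds shown here, no measured step covers exactly this change. For the measured compounds named here, the only related evidence comes from compound 1, which shares the 2-hydroxyethyl group with compound 4 while differing from it elsewhere, and whose value in this assay is far lower than that of compound 3. A step of roughly a 10-fold lower number from compound 3 to compound 4 (1.01 log units; beyond the scatter) toward a lower number is therefore expected. Compound 4 is estimated at 40000 nM, with a likely range from 10000 nM to 160000 nM.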

Compound 4, half-maximal inhibitory concentration: 42100 nM
Compound 4: the middle estimate sits 1.1-fold (0.02 log units) below what was measured; measured number inside the range.
By their numbers in this assay, from the lowest: compounds 1 and 4 (each within the scatter of the next); then compounds 2 and 3 (each within the scatter of the next).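

In this assay, among the compounds shown here, the step of a 9.7-fold lower number from compound 3 to compound 4 (0.99 log units; beyond the scatter) gives the first direct reading of this change: on the amine nitrogen whose other neighbour is the double-bonded nitrogen, 2-hydroxyethyl in place of methoxycarbonyl shifts the number beyond the scatter, whereas the amino-for-hydrogen change on the aromatic carbon stayed within it. The second step, a 1.5-fold higher number from compound 1 to compound 4 (0.18 log units; within the scatter), lies within the scatter, so between these two compounds, both carrying 2-hydroxyethyl, chloro or hydrogen on the aromatic carbon makes no clear difference to the read-out. Nothing measured here tells what lies behind either step.

The swap removes a whole methoxycarbonyl group and brings in a chain ending in a hydroxyl, so the compounds shown cannot separate the loss of the one from the gain of the other; a plain ethyl group, a 2-aminoethyl chain or a longer 3-hydroxypropyl chain on the same nitrogen would begin to do that. As far as these compounds go, it also remains open whether the swap gives a step of similar size on the core of compound 2, which has hydrogen where compound 3 has amino.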